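Cytotoxicity notes: compound 2 to compound 4

A few compounds are considered here, and "the series" means these few. Any claim that something is new, unique, unknown or untested is made for them only; others in the source may bear on it.

Compound 1 `CC(Sc1nnc(-c2ccncc2)s1)C(=O)Nc1ccccc1` gives > 50000 nM in an ADME assay on BHK-21 cells (Mesocricetus auratus) for cytotoxicity, with a stated time of 3 days (on this read-out higher numbers stand for lower toxicity in this test and lower numbers for higher toxicity in this test), a limit of the assay.
Compound 2 `CC(CSc1nnc(-c2ccncc2)s1)C(=O)Nc1ccc(Cl)cc1Cl` gives > 50000 nM in this assay, a limit of the assay.
Compound 3 `O=C(CCSc1nnc(-c2ccncc2)s1)Nc1ccc(Cl)cc1Cl` gives > 50000 nM, again a limit.

Compound 2 therefore has no number of its own in this assay; it sits at the limit where all measured values of the series sit (the limit of > 50000 nM in this assay, at which 3 of the 3 values shown sit). Among the compounds with values here, the one step that can be drawn among measured compounds is a step that the two limits leave unreadable from compound 2 to compound 3, and with both ends at the limit its size cannot be read.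

The next compound, compound 4 `CC(CSc1nnc(-c2ccncc2)s1)C(=O)Nc1ccccc1Cl`, differs from compound 2 by hydrogen in place of chloro on an aromatic carbon.

Within the data shown here, no measured step touches a change of this kind, and the only recorded step is unreadable, so no size and no direction can be taken from the measured compounds. Given that every value so far sits at the limit (the limit of > 50000 nM in this assay, at which 3 of the 3 values shown sit), compound 4 is expected to sit there too, with the step of a number no higher from compound 2 to compound 4 (the limit leaves the size open) expected to stay within scatter. The estimate for compound 4 in this assay is 50000 nM, expected between 25000 nM and 100000 nM, most likely reported only as a limit.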

Compound 4, half-maximal cytotoxic concentration: > 50000 nM
Compound 4: no number, only a limit (the forecaster's own chance of this, stated with the estimate: 85%); the middle value sits exactly at the limit.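

Compound 4 gives > 50000 nM in this assay, a limit and not a number. Compound 2 also stands only at a limit, so no new step can be read between compound 2 and compound 4: the limit of > 50000 nM in this assay, at which 4 of the 4 values shown sit.

The compounds shown leave open whether 2,4-dichlorophenyl to 2-chlorophenyl changes cytotoxicity at all, and at what concentration any of them becomes toxic.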